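Methyl Loss on a Five-Membered Ring: Expecting Compound 4

This account rests on a few compounds, and the source may have more. Where it says the series, first, only, none or still open, it means among the compounds named here.

Compound 1 `Cc1cnn(C(=O)NCc2ccc(OC(c3ccccc3)c3ccccc3)cc2)c1`: in an assay on membranes from brain for binding affinity to Monoglyceride lipase (Mus musculus), read by fluorescence, with stated times of 1 h and 30 min (on this read-out higher numbers stand for weaker inhibition and lower numbers for stronger inhibition), compound 1 gives > 100000 nM, which is a limit of the assay and not a number.
Compound 2 `O=C(NCc1ccc(OC(c2ccccc2)c2ccccc2)cc1)n1cccn1`: in this assay compound 2 gives > 100000 nM, again only a limit.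
Compound 3 `Cc1cnn(C(=O)N(C)CCN(C)C(c2ccc(OCc3ccccc3)cc2)c2ccc(OCc3ccccc3)cc2)c1`: in this assay compound 3 gives > 1000000 nM, also a limit.

Compound 1 and compound 2 differ by hydrogen in place of methyl on an aromatic carbon. The step that the two limits leave unreadable from compound 1 to compound 2 cannot be sized, because both values sit at the limit of > 100000 nM in this assay, at which 2 of the 3 values shown sit. Compound 3 rests at the limit of > 1000000 nM in this assay, at which 1 of the 3 values shown sits, so for it too only a limit is known. The cores of compound 1 and compound 3 differ in more than one place, and that difference is not broken down here.

Compound 4 `CN(CCN(C)C(c1ccc(OCc2ccccc2)cc1)c1ccc(OCc2ccccc2)cc1)C(=O)n1cccn1` is the unmeasured partner of compound 3. It differs from compound 3 by hydrogen in place of methyl on an aromatic carbon, the same change that links compound 1 to compound 2, and at the same place in both pairs. Since that change left compound 1 and compound 2 both without measurable inhibition, and since compound 3 itself shows only a limit, the expected outcome for compound 4 in this assay is again a value at or beyond the reporting limit, meaning an expected step of a number no higher from compound 3 to compound 4 (the limit leaves the size open). The estimate for compound 4 is therefore 1000000 nM, with a range from 100000 nM to 5000000 nM.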

Compound 4, half-maximal inhibitory concentration: > 1000000 nM
Compound 4: only a limit was reported; the forecaster's own chance of this, stated with the estimate: 90%; the middle value lies on the limit itself.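

In this assay compound 4 gives > 1000000 nM, which is a limit of the assay and not a number. Compound 3 also stands only at a limit, so no step from compound 3 to compound 4 can be read: the limit of > 1000000 nM in this assay, at which 2 of the 4 values shown sit.

The compounds shown leave open whether going from 4-methyl-1H-pyrazol-1-yl to 1H-pyrazol-1-yl changes inhibition at all, as none of them gives an actual number.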